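Moving a methoxy from one ring position to another in sulfonate esters

This account rests on a few compounds, and the source may have more. Where it says the series, first, only, none or still open, it means among the compounds named here.

Measured so far in a functional assay on M21 cells (Homo sapiens) for antiproliferative activity, read by sulforhodamine B assay, with a stated time of 48 h; a lower number here means a stronger inhibitor, a higher number a weaker inhibitor:
compound 1 `CCN1CCN(c2ccc(S(=O)(=O)Oc3ccccc3OC)cc2)C1=O` > 100000 nM
compound 2 `CCN1CCN(c2ccc(S(=O)(=O)Oc3cccc(OC)c3)cc2)C1=O` 7000 nM
compound 3 `CCCCN1CCN(c2ccc(S(=O)(=O)Oc3ccccc3OC)cc2)C1=O` > 100000 nM

The value of compound 1 in this assay is a limit, not a number. The value of compound 3 is likewise a limit (the limit of > 100000 nM in this assay, at which 2 of the 3 values shown sit). Compound 2 gives a number, and the step of an at least 14-fold lower number from compound 1 to compound 2 (1.15 log units; beyond the scatter) comes from the change (3-methoxyphenyl in place of 2-methoxyphenyl on an oxygen). The step that the two limits leave unreadable from compound 1 to compound 3 cannot be sized, as both ends are limits; the cores differ by ethyl in place of hydrogen on a saturated chain carbon, two bonds along the chain from an amide-type nitrogen in a ring.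

Compound 4 `CCCCN1CCN(c2ccc(S(=O)(=O)Oc3cccc(OC)c3)cc2)C1=O` has not been measured. It differs from compound 3 by 3-methoxyphenyl in place of 2-methoxyphenyl on an oxygen, the same change as from compound 1 to compound 2, at the same place. Because the earlier step of an at least 14-fold lower number from compound 1 to compound 2 (1.15 log units; beyond the scatter) was large, a step of similar size, an at least 10-fold lower number from compound 3 to compound 4 (1.00 log units; beyond the scatter), is expected here, though the core of compound 3 has not been tested with this change. Compound 4 is estimated at 10000 nM, with a range from 2000 nM to 60000 nM.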

Compound 4, half-maximal inhibitory concentration: 30000 nM
The estimate for compound 4 lay 3.0-fold (0.48 log units) below the measured number, and the stated range covers the measured number.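

Placing 3-methoxyphenyl in place of 2-methoxyphenyl on the core of compound 3 gave an at least 3.3-fold lower number from compound 3 to compound 4 (0.52 log units; beyond the scatter) in this assay, so the change lowered the number on both cores shown. This does not show that the change has the same size on both cores: the same change on two cores in this assay, an at least 14-fold lower number (1.15 log units; beyond the scatter) from compound 1 to compound 2 and an at least 3.3-fold lower number (0.52 log units; beyond the scatter) from compound 3 to compound 4; the limit leaves it open whether they differ

With 3-methoxyphenyl in place, the added ethyl gave a 4.3-fold higher number from compound 2 to compound 4 (0.63 log units; beyond the scatter), whereas the matching step with 2-methoxyphenyl cannot be read, as both of its ends are limits. The compounds shown leave open whether the change would carry over to a core with a longer chain. They also leave open how an unsubstituted phenyl or a carboxylic acid in place of the methoxy would read.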